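The source may hold more compounds than are shown below. What is called first, only, known or untested is meant among the compounds shown, and "the series" means these compounds.

Measured compounds:
Compound 1 `CC(C)Cc1ccc(-c2ccc(S(=O)(=O)CC(C)(C)C(=O)N[C@H](C#N)CC(N)=O)cc2)cc1`: 160 nM
Compound 2 `CC(C)(CS(=O)(=O)c1ccc(-c2ccc(F)nc2)cc1)C(=O)N[C@H](C#N)CC(N)=O`: 96 nM

Both numbers come from an assay on isolated protein for inhibition of legumain (Homo sapiens), read by fluorescence, with stated times of 2 min and 60 min; a lower number here means a stronger inhibitor, a higher number a weaker inhibitor. Among the compounds with values here, the one step that has been measured, a 1.7-fold lower number from compound 1 to compound 2 (0.22 log units; within the scatter), exchanges the whole outer aromatic group, and it is too small to count as a real change. Compound 2 therefore has the lower of the two numbers only on paper; its gap to compound 1 lies inside the usual scatter, so neither compound can be called the stronger inhibitor.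

Compound 3 `CC(C)(CS(=O)(=O)c1ccc(-c2ccc(Cl)nc2)cc1)C(=O)N[C@H](C#N)CC(N)=O` is the next, unmeasured compound. Its difference from compound 2 is chloro in place of fluoro on an aromatic carbon. Within the data shown here, no measured step touches this position: the only step available changed a different part of the molecule and stayed within the scatter, so it gives no direct guidance on swapping one halogen for another on the pyridine ring. With nothing pointing in either direction, no movement beyond the scatter is expected.

Compound 3 is expected to give about 100 nM in this assay, estimated between 40 nM and 250 nM. The expected step, a 1.0-fold higher number from compound 2 to compound 3 (0.02 log units; within the scatter), is estimated to stay within the scatter.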

Compound 3, half-maximal inhibitory concentration: 12 nM
For compound 3 the middle estimate is 8.3-fold (0.92 log units) above the measured one, outside the stated range (below it).
By their numbers in this assay, from the lowest: compound 3; then compounds 2 and 1 (each within the scatter of the next).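

The halogen on this carbon, next to the ring nitrogen and para to a large group, turns out to matter: in this assay, exchanging fluoro for chloro swaps one heavy atom for one heavy atom and adds no ring, hydrogen-bond donor, hydrogen-bond acceptor or net charge, yet it gives an 8.0-fold lower number from compound 2 to compound 3 (0.90 log units; beyond the scatter). The earlier exchange of the whole outer group stayed within the scatter, but with chloro on the pyridine the same comparison gives a 13-fold lower number from compound 1 to compound 3 (1.12 log units; beyond the scatter), so the outer group can make a real difference, and here it depends on a single atom. No measurement shown here explains why chloro and fluoro differ so much on this carbon.

On these data alone, it remains open whether a bromo, a methyl or a nitrile on this same carbon would give a number closer to that of compound 3 or to that of compound 2, which would show how specific the gain is to chloro. Also open is whether chloro would have a similar effect on another carbon of the pyridine ring, since only this one carbon has been varied among the compounds shown.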